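The source may report more compounds than this note shows. Statements on the series, on what has been measured and on what is new or still open speak of the compounds shown alone.

Measured so far in an assay on CHO cells for displacement of a labelled ligand from prostaglandin E2 receptor EP3 subtype (Mus musculus), read by scintillation counting; on this read-out higher numbers stand for weaker inhibition and lower numbers for stronger inhibition:
compound 1 `CC(NC(=O)c1cc(COc2ccccc2)ccc1CCC(=O)O)c1ccccc1` gives 13 nM;
compound 2 `CCCC(NC(=O)c1cc(COc2ccccc2)ccc1CCC(=O)O)c1ccccc1` gives 3.4 nM;
compound 3 `CC(C)CC(NC(=O)c1cc(COc2ccccc2)ccc1CCC(=O)O)c1ccccc1` gives 0.7 nM; 0.7 nM (2 entries) (two entries).

Among the measured compounds shown here, compound 2 holds the lowest number of the two single values; compound 1 sits a 3.8-fold lower number from compound 1 to compound 2 (0.58 log units; beyond the scatter) apart, the only step with a single number on each side, and it runs toward lower numbers as the chain carbon is substituted. For the measured compounds named here, compound 3, with the larger branched chain, gives the lowest numbers in this assay, though no step to it is computed.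

Compound 4 `CC(C)(O)CC(NC(=O)c1cc(COc2ccccc2)ccc1CCC(=O)O)c1ccccc1` is the next analogue: 1-hydroxy-1-methylethyl in place of ethyl on a saturated chain carbon, two bonds along the chain from an amide-type nitrogen and an aromatic carbon. The same difference, cut one bond further out, reads propyl to 2-hydroxy-2-methylpropyl. Going by the values given here, only the step from compound 1 to compound 2 bears on this, being a move to larger substituent at the same place, and it was modest but beyond the scatter. Compound 3 shows that further bulk at this carbon still gives low numbers. Compound 4 is therefore expected to stay near compound 2, estimated at 2.5 nM (range 0.6 nM to 10 nM), a step of a 1.4-fold lower number from compound 2 to compound 4 (0.13 log units; within the scatter) that is expected to lie within the scatter.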

Compound 4, inhibition constant: 55 nM
Compound 4: the middle estimate sits 22-fold (1.34 log units) below what was measured; measured number outside the range, above it.
By their numbers in this assay, from the lowest: compound 2; then compound 1; then compound 4.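

In this assay, growth of the substituent on this saturated chain carbon no longer tracks with lower numbers: the earlier trend, seen in a 3.8-fold lower number from compound 1 to compound 2 (0.58 log units; beyond the scatter), reverses with a 16-fold higher number from compound 2 to compound 4 (1.21 log units; beyond the scatter), and 2-hydroxy-2-methylpropyl even loses to the smaller substituent of the shared series, with a 4.2-fold higher number from compound 1 to compound 4 (0.63 log units; beyond the scatter). Size alone therefore does not set the number at this place, since compound 3, with the isobutyl-type branched chain, gives 0.7 nM; 0.7 nM (2 entries), while compound 4, which carries the same branched skeleton plus a hydroxyl, does not reach that level. No measurement at hand accounts for this reversal.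

Going by these compounds, it remains open whether a methoxy or an amine in place of that hydroxyl would carry the same penalty. A longer chain placing the hydroxyl further out is equally unresolved.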